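Replacing 4-chlorobenzyl with 3-(trifluoromethyl)benzyl: a modest rise expected

This account rests on a few compounds, and the source may have more. Where it says the series, first, only, none or still open, it means among the compounds named here.

Measured in a functional assay on HepG2 cells (Homo sapiens) for antiproliferative activity, read by MTT assay, with a stated time of 24 h; on this read-out lower numbers stand for stronger inhibition and higher numbers for weaker inhibition:
- compound 1 `COc1cc(OC)c(-c2coc3cc(OCc4ccc([N+](=O)[O-])cc4)ccc3c2=O)cc1OC` gives 2500 nM
- compound 2 `COc1cc(OC)c(-c2coc3cc(OCc4ccccc4C#N)ccc3c2=O)cc1OC` gives > 10000 nM, which is a limit of the assay and not a number
- compound 3 `COc1cc(OC)c(-c2coc3cc(OCc4ccc(Cl)cc4)ccc3c2=O)cc1OC` gives 940 nM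

Compound 3 has the lowest value shown, and the nearest number belongs to compound 1. Compound 4 `COc1cc(OC)c(-c2coc3cc(OCc4cccc(C(F)(F)F)c4)ccc3c2=O)cc1OC` carries 3-(trifluoromethyl)phenyl in place of 4-chlorophenyl on a saturated chain carbon bound to an oxygen on an aromatic ring. For the measured compounds named here, two measured steps bear on this position: a 2.7-fold lower number from compound 1 to compound 3 (0.42 log units; beyond the scatter) and an at least 10-fold lower number from compound 2 to compound 3 (1.02 log units; beyond the scatter). Both end at compound 3, so neither other group matched its 4-chlorophenyl. A modest rise is therefore expected in this assay. The expected step is a 2.3-fold higher number from compound 3 to compound 4 (0.37 log units; beyond the scatter). The estimate for compound 4 is 2200 nM, with an expected range of 700 nM to 7000 nM.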

Compound 4, half-maximal inhibitory concentration: 610 nM
The estimate for compound 4 lay 3.6-fold (0.56 log units) above the measured number, outside the stated range (below it).
By their numbers in this assay, from the lowest: compounds 4 and 3 (each within the scatter of the next); then compound 1. At a limit, above all of these: compound 2.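

For the compounds shown here, with a 1.5-fold lower number from compound 3 to compound 4 (0.19 log units; within the scatter), 3-(trifluoromethyl)phenyl is the first group at this position to match 4-chlorophenyl, so two differently substituted phenyl groups now read alike here. It also separates from 4-nitrophenyl, with a 4.1-fold lower number from compound 1 to compound 4 (0.61 log units; beyond the scatter). The gap to 2-cyanophenyl, an at least 16-fold lower number from compound 2 to compound 4 (1.21 log units; beyond the scatter), rests on a limit and not a number: the limit of > 10000 nM in this assay, at which 1 of the 4 values shown sits.

Going by these compounds, it remains open what a 4-cyanophenyl group would give at this position, which would set the nitrile apart from the 2-cyanophenyl result. Also open, on these data alone, is whether the aromatic ring is needed at all, as a longer chain or an amine in its place could show.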